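Isopropyl for Hydroxyethyl on a Sulfonamide Chain

The compounds below may be only part of what the source reports. "The series", "measured", "known", "first", "only" and "open" are said of these compounds alone.

Compound 1 `CC[C@@H]1C(=O)N(C)c2cnc(-n3ccc4cc(F)ccc43)nc2N1C1CCCC1`: in a functional assay on A549 cells (Homo sapiens) for antiproliferative activity, read by CCK-8 assay, with a stated time of 72 h (on this read-out higher numbers stand for weaker inhibition of growth and lower numbers for stronger inhibition of growth), compound 1 reads "not active" (no number reported).
Compound 2 `CC[C@@H]1C(=O)N(C)c2cnc(Nc3ccc(S(=O)(=O)NC4CCCC4)cc3)nc2N1C1CCCC1`: compound 2 gives 1150 nM.
Compound 3 `CCC1C(=O)N(C)c2cnc(Nc3ccc(S(=O)(=O)NCCCO)cc3)nc2N1c1ccn(C)n1`: compound 3 gives 48900 nM.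

Compound 3 stands highest of the two numbers in this assay, with compound 2 its nearest neighbour by a gap far beyond the usual scatter; compound 1 contributes no number. Compound 4 `CCC1C(=O)N(C)c2cnc(Nc3ccc(S(=O)(=O)NCC(C)C)cc3)nc2N1c1ccn(C)n1` differs from compound 3 in one place: isopropyl in place of 2-hydroxyethyl on a saturated chain carbon bound to a sulfonamide nitrogen. Among the measured compounds shown here, no pair among the measured compounds isolates this change, so nothing here shows its direction. The step of a 1.6-fold lower number from compound 3 to compound 4 (0.21 log units; within the scatter) is therefore expected to be small, plausibly within the scatter. Compound 4 is estimated at 30000 nM, between 8000 nM and 100000 nM.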

Compound 4, concentration for 50% growth inhibition: 31600 nM
Estimate against measurement, compound 4: 1.1-fold (0.02 log units) below; the range from low to high includes it.
By their numbers in this assay, from the lowest: compound 2; then compounds 4 and 3 (each within the scatter of the next).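

In this assay, among the compounds shown here, this pair is the first to isolate the change, and it gives a 1.5-fold lower number from compound 3 to compound 4 (0.19 log units; within the scatter). At this position on the sulfonamide chain, isopropyl in place of 2-hydroxyethyl therefore leaves the reading within the scatter, even though the hydrogen-bond donor and acceptor counted on the group that leaves are absent from the group that enters. No available evidence bears on the reason for this result. On these data alone, whether an amine, a carboxylic acid or a longer chain at this place would shift the reading remains open.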